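Trifluoromethyl placement on the shared core

The compounds below may be only part of what the source reports. "The series", "measured", "known", "first", "only" and "open" are said of these compounds alone.

Measured so far in an assay on isolated protein for displacement of a labelled ligand from D(4) dopamine receptor (Homo sapiens); a higher number here means a weaker inhibitor, a lower number a stronger inhibitor:
compound 1 `O=C(NC1CCN(Cc2cccc(Cl)c2)CC1)c1ccc2ccccc2c1`: 54 nM
compound 2 `O=C(NC1CCN(Cc2cccc(Br)c2)CC1)c1ccc2ccccc2c1`: 36 nM
compound 3 `O=C(NC1CCN(Cc2cccc(C(F)(F)F)c2)CC1)c1ccc2ccccc2c1`: 103 nM

Compound 3 carries the highest of the three numbers. Against compound 1 the gap is a 1.9-fold higher number from compound 1 to compound 3 (0.28 log units; within the scatter); against compound 2 it is a 2.9-fold higher number from compound 2 to compound 3 (0.46 log units; beyond the scatter). Compound 4 `O=C(NC1CCN(Cc2ccc(C(F)(F)F)cc2)CC1)c1ccc2ccccc2c1` differs from compound 3 by 4-(trifluoromethyl)phenyl in place of 3-(trifluoromethyl)phenyl on a saturated chain carbon bound to an amine nitrogen in a ring. The measured steps all exchange one substituent for another at the same place on the ring, so none bears directly on moving the trifluoromethyl group to another position; they only show that this part of the core tolerates change of modest size. Going by the values given here, with no directly relevant step, no movement beyond the scatter is expected in this assay. Compound 4 is therefore estimated at 100 nM, with a range of 40 nM to 260 nM. The expected step is a 1.0-fold lower number from compound 3 to compound 4 (0.01 log units; within the scatter).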

Compound 4, inhibition constant: 84 nM
Beside the measured number, compound 4's estimate is 1.2-fold (0.08 log units) above it; measured number inside the range.
By their numbers in this assay, from the lowest: compounds 2, 1, 4 and 3 (each within the scatter of the next, the first and the last beyond it).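

In this assay, moving the trifluoromethyl group on this saturated chain carbon gives a 1.2-fold lower number from compound 3 to compound 4 (0.09 log units; within the scatter) and so leaves the number unresolved between the 3- and 4-(trifluoromethyl)phenyl groups. The position of the group therefore shows no effect beyond the scatter in this pair, and the comparison with the halogen compounds keeps the same shape: a 1.6-fold higher number from compound 1 to compound 4 (0.19 log units; within the scatter) and a 2.3-fold higher number from compound 2 to compound 4 (0.37 log units; beyond the scatter) are the printed gaps. No supporting data account for these steps.

On these data alone, whether chloro or bromo tolerates the same move remains open. So does whether a ring amine or carboxylic acid would shift the number beyond the scatter.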